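The compounds below may be only part of what the source reports. "The series", "measured", "known", "first", "only" and "open" are said of these compounds alone.

Of the compounds shown here, two have so far been measured in a functional assay on HeLa cells (Homo sapiens) for antiproliferative activity, read by MTT assay, with a stated time of 72 h; a lower number here means a stronger inhibitor, a higher number a weaker inhibitor. Compound 1 `COc1ncc(-c2ccc3c(c2)N(c2ccc(C)cc2)C(=O)CO3)cc1NS(=O)(=O)c1ccc(F)cc1` gives 4650 nM in this assay, the lower of the two numbers recorded. Compound 2 `O=C1COc2ccc(-c3cccc(NS(=O)(=O)c4ccc(F)cc4)c3)cc2N1c1ccccc1` gives 17700 nM in this assay, and its gap from compound 1 lies beyond the usual scatter of repeated measurements, so compound 1 stands as the stronger inhibitor of the pair. Compound 3 `COc1ncc(-c2ccc3c(c2)N(c2ccc(Cl)cc2)C(=O)CO3)cc1NS(=O)(=O)c1ccc(F)cc1` has not yet been measured. It differs from compound 1 in a single place: chloro in place of methyl on an aromatic carbon. For the measured compounds named here, no measured pair shows this particular swap, so the data give no size for it. The expected step from compound 1 to compound 3 in this assay is one that stays within the scatter, with no clear direction: a 1.2-fold lower number from compound 1 to compound 3 (0.07 log units; within the scatter). Compound 3 is therefore estimated to give 4000 nM in this assay, with a plausible range from 1500 nM to 12000 nM.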

Compound 3, half-maximal inhibitory concentration: 4830 nM
Beside the measured number, compound 3's estimate is 1.2-fold (0.08 log units) below it; the range from low to high includes it.
By their numbers in this assay, from the lowest: compounds 1 and 3 (each within the scatter of the next); then compound 2.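

Putting chloro in place of methyl on the aromatic carbon para to a large group gives, in this assay, a 1.0-fold higher number from compound 1 to compound 3 (0.02 log units; within the scatter). For the compounds shown here, this is the first direct reading of any single change, since compounds 1 and 2 differ in more than one place, and it shows that this exchange at this position leaves the number within the scatter. Nothing measured here offers an explanation for this result.

Going by these compounds alone, this is still only one swap at one position, so it cannot show whether the number would hold with an amine, a carboxylic acid or a longer chain such as propyl in that place. It also leaves open whether the same exchange would read the same way on a different core or in a different assay.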